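This account rests on a few compounds, and the source may have more. Where it says the series, first, only, none or still open, it means among the compounds named here.

Of the compounds shown here, three of a shared core have been measured in an ADME assay on A549 cells (Homo sapiens) for cytotoxicity, read by resazurin assay, with a stated time of 48 h; a lower number here means that less compound is tolerated, a higher number that more compound is tolerated. Compound 1 `CCCCCCCCC(C)Nc1ccc(NC(=O)c2cc(Cl)ccc2O)c(Cl)c1` gives 21900 nM. Compound 2 `O=C(Nc1ccc(NCC2CC2)cc1Cl)c1cc(Cl)ccc1O` gives 14400 nM. Compound 3 `CCCN(CCC)c1ccc(NC(=O)c2cc(Cl)ccc2O)c(Cl)c1` gives 10700 nM, the lowest of the three numbers: its gap to compound 2 is within the scatter, while its gap to compound 1 is beyond it, so among these three only compound 1 can be said to be tolerated at clearly higher concentration.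

Compound 4 `O=C(Nc1ccc(NCc2cccnc2Cl)cc1Cl)c1cc(Cl)ccc1O` is not yet measured. It differs from compound 3 in one place: ((2-chloropyridin-3-yl)methyl)amino in place of dipropylamino on an aromatic carbon. Within the data shown here, the one measured step that bears on this is the earlier exchange at the same aromatic carbon, a 1.3-fold lower number from compound 2 to compound 3 (0.13 log units; within the scatter), which changed the number by an amount within the scatter. Compound 2, carrying a (cyclopropylmethyl)amino group, and compound 1, carrying a secondary amino group with a long chain, both sit at or above compound 3, and neither step at this position produced a large shift. The expected step of a 1.4-fold higher number from compound 3 to compound 4 (0.15 log units; within the scatter) is therefore a small rise, and on these few points a change within the scatter is as likely as one just beyond it. Compound 4 is estimated at 15000 nM, with a range from 7000 nM to 32000 nM.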

Compound 4, half-maximal cytotoxic concentration: 101000 nM
Compound 4: middle estimate off by 6.7-fold (0.83 log units), on the low side; the measured number lies above the stated range.
By their numbers in this assay, from the lowest: compounds 3, 2 and 1 (each within the scatter of the next, the first and the last beyond it); then compound 4.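

In this assay this position proves far less flat than the earlier exchange suggested: putting ((2-chloropyridin-3-yl)methyl)amino in place of dipropylamino gives a 9.4-fold higher number from compound 3 to compound 4 (0.97 log units; beyond the scatter) and stands well apart from the small gaps among compounds 1, 2 and 3. The comparison with compound 2 is narrower still, as only cyclopropyl gives way to 2-chloropyridin-3-yl on the chain carbon bound to the nitrogen, and that single exchange gives a 7.0-fold higher number from compound 2 to compound 4 (0.85 log units; beyond the scatter) while the amino hydrogen stays in place. Compound 4 is also the only one of the four with an aromatic ring in this group, yet no measurement at hand says why that goes with a higher tolerated concentration.

Whether the rise belongs to the ring as such, to its ring nitrogen or to its chlorine stays open: a plain benzyl group and a pyridinylmethyl group without the chlorine are not among the compounds shown. As far as these compounds go, it is equally open how a carboxylic acid or a morpholine ring on this carbon would read in this assay and how far the rise extends to other aromatic groups.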